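From 3-nitrophenyl to 4-nitrophenyl on the shared core

The source may hold more compounds than are shown below. What is called first, only, known or untested is meant among the compounds shown, and "the series" means these compounds.

Values in a functional assay on MCF7 cells (Homo sapiens) for antiproliferative activity, read by MTT assay, with stated times of 24 h and 72 h (a lower number here means a stronger inhibitor, a higher number a weaker inhibitor), so far:
- compound 1 `COc1cc(N2C(=O)[C@@H](Oc3ccccc3)[C@H]2c2ccc(C#N)cc2)cc(OC)c1OC` gives 31600 nM
- compound 2 `COc1cc(N2C(=O)[C@@H](Oc3ccccc3)[C@H]2c2cccc3ccccc23)cc(OC)c1OC` gives 53000 nM
- compound 3 `COc1cc(N2C(=O)[C@@H](Oc3ccccc3)[C@H]2c2cccc([N+](=O)[O-])c2)cc(OC)c1OC` gives 30000 nM

Compound 3 stands within the scatter of both others, with a 1.1-fold lower number from compound 1 to compound 3 (0.02 log units; within the scatter) and a 1.8-fold lower number from compound 2 to compound 3 (0.25 log units; within the scatter) as its two steps. From the compounds shown here alone, compound 4 `COc1cc(N2C(=O)[C@@H](Oc3ccccc3)[C@H]2c2ccc([N+](=O)[O-])cc2)cc(OC)c1OC` is still open. The change is 4-nitrophenyl in place of 3-nitrophenyl on a saturated ring carbon. All measured steps sit at this same place, and the third, a 1.7-fold higher number from compound 1 to compound 2 (0.22 log units; within the scatter), also stays within the scatter. None of them compares the two nitrophenyl groups directly, yet on this evidence no step beyond the scatter is expected in this assay. The estimated step is no change at the digits printed from compound 3 to compound 4 (within the scatter) in this series. For compound 4 the expected value is 30000 nM, with an estimated range of 12000 nM to 60000 nM.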

Compound 4, half-maximal inhibitory concentration: 63000 nM
Estimate against measurement, compound 4: 2.1-fold (0.32 log units) below; the measured number lies above the stated range.
By their numbers in this assay, from the lowest: compounds 3, 1, 2 and 4 (each within the scatter of the next, the first and the last beyond it).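

In this assay, within the data shown here, this place on the shared core responds to a shift of the nitro group alone: a 2.1-fold higher number from compound 3 to compound 4 (0.32 log units; beyond the scatter) is the first step beyond the scatter, though a modest one. The other new steps stay within the scatter, with a 1.2-fold higher number from compound 2 to compound 4 (0.08 log units; within the scatter) and a 2.0-fold higher number from compound 1 to compound 4 (0.30 log units; within the scatter) as printed, so the separation holds only against compound 3. Nothing measured here accounts for the gap between the two nitrophenyl groups.

From the compounds shown here alone, whether an aminophenyl or a carboxyphenyl group at this place would follow either nitrophenyl group remains open.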